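The source may report more compounds than this note shows. Statements on the series, on what has been measured and on what is new or still open speak of the compounds shown alone.

The three measured compounds, with their results in a functional assay on MCF7 cells (Homo sapiens) for antiproliferative activity, read by sulforhodamine B assay, with a stated time of 48 h; on this read-out lower numbers stand for stronger inhibition and higher numbers for weaker inhibition:

Compound 1, `CN1CCN(c2ccc(S(=O)(=O)Oc3cccc(Br)c3)cc2)C1=O`, gives 1500 nM.
Compound 2, `CN1CCN(c2ccc(S(=O)(=O)Oc3cccc(I)c3)cc2)C1=O`, gives 560 nM.
Compound 3, `CCN1CCN(c2ccc(S(=O)(=O)Oc3cccc(Br)c3)cc2)C1=O`, gives 2500 nM.

Compound 2 differs from compound 1 in a single place on the halogen-bearing ring: iodo in place of bromo on an aromatic carbon. This change produced a 2.7-fold lower number from compound 1 to compound 2 (0.43 log units; beyond the scatter), a clear if modest gain in potency. Compound 3 differs from compound 1 elsewhere, and that change produced a 1.7-fold higher number from compound 1 to compound 3 (0.22 log units; within the scatter), so compound 1 and compound 3 cannot be separated on this read-out. Among the compounds with values here, no single step links compound 3 and compound 2; of the two, compound 2 has the lower number.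

Compound 4, `CCN1CCN(c2ccc(S(=O)(=O)Oc3cccc(I)c3)cc2)C1=O`, has not yet been measured. It stands to compound 3 exactly as compound 2 stands to compound 1: iodo in place of bromo on an aromatic carbon. The place of the change is described in the same words for both pairs, so this is the same change made on two closely related cores, which differ only by methyl in place of hydrogen on a saturated chain carbon bound to an amide-type nitrogen in a ring.

Since the same change lowered the number between compound 1 and compound 2 by a 2.7-fold lower number from compound 1 to compound 2 (0.43 log units; beyond the scatter), a step of similar size is expected from compound 3, namely a 2.6-fold lower number from compound 3 to compound 4 (0.42 log units; beyond the scatter). On that basis, compound 4 is estimated to give 950 nM in this assay. Allowing for repeat scatter on both sides, compound 4 is expected to fall between 400 nM and 2200 nM.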

Compound 4, half-maximal inhibitory concentration: 1900 nM
Estimate against measurement, compound 4: 2.0-fold (0.30 log units) below, within the range that was stated.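

In this assay, the swap of bromo for iodo, carried over to the core with the added methyl, gives a 1.3-fold lower number from compound 3 to compound 4 (0.12 log units; within the scatter), so on this core alone it cannot be told from repeat scatter, yet this step does not truly differ from the earlier one: the same change on two cores in this assay, a 2.7-fold lower number (0.43 log units; beyond the scatter) from compound 1 to compound 2 and a 1.3-fold lower number (0.12 log units; within the scatter) from compound 3 to compound 4, 2.0-fold (0.31 log units) apart, within the scatter of two such steps. Read the other way, the added methyl between the two iodo compounds gives a 3.4-fold higher number from compound 2 to compound 4 (0.53 log units; beyond the scatter), which passes the scatter where the same change between the two bromo compounds did not, but again the two steps cannot be separated: the same change on two cores in this assay, a 1.7-fold higher number (0.22 log units; within the scatter) from compound 1 to compound 3 and a 3.4-fold higher number (0.53 log units; beyond the scatter) from compound 2 to compound 4, 2.0-fold (0.31 log units) apart, within the scatter of two such steps. The result therefore fits a halogen swap that carries from one core to the other, but it does not prove this, and two pairs cannot show whether the step is truly the same size on both cores or somewhat weaker on the second.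

The compounds shown leave open how a chloro, methoxy or nitrile group would behave in place of the halogen on the 3-bromophenoxy ring. They also leave open what a longer chain, such as propyl or butyl, or a chain ending in an amine would do in place of the methyl or ethyl on the shared core.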